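Dichlorinated cores and a second benzyl substitution pattern

The source may report more compounds than this note shows. Statements on the series, on what has been measured and on what is new or still open speak of the compounds shown alone.

Of the compounds shown here, three have been measured in a functional assay on A498 cells (Homo sapiens) for cytotoxicity, read by sulforhodamine B assay, with a stated time of 48 h; on this read-out lower numbers stand for stronger inhibition of growth and higher numbers for weaker inhibition of growth. Compound 1 `ClCc1cccc(Cn2cnc3ncnc(Cl)c32)c1` carries a single chloro group on its fused core; in this assay compound 1 gives 18200 nM. Compound 2 `ClCc1ccccc1Cn1cnc2ncnc(Cl)c21` shares the same atoms but joins them differently; how the two cores differ is not broken down here. In this assay compound 2 gives 18600 nM, which lies within the scatter of the value for compound 1. Compound 3 `ClCc1cccc(Cn2cnc3nc(Cl)nc(Cl)c32)c1` keeps the benzyl arrangement of compound 1 and adds a second chloro group to the core; in this assay compound 3 gives 1510 nM.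

The change from compound 1 to compound 3 is chloro in place of hydrogen on an aromatic carbon and it produced a 12-fold lower number from compound 1 to compound 3 (1.08 log units; beyond the scatter).

Compound 4 `ClCc1ccccc1Cn1cnc2nc(Cl)nc(Cl)c21` has not yet been measured. It stands to compound 2 as compound 3 stands to compound 1: the change is chloro in place of hydrogen on an aromatic carbon, the same change, occurring twice among these compounds. The account therefore rests on a single observed step. Within the data shown here, since the core of compound 2 gave a value within the scatter of compound 1, the expectation is that the second chloro group will act as it did from compound 1 to compound 3, and the step from compound 2 to compound 4 is estimated as a 12-fold lower number from compound 2 to compound 4 (1.07 log units; beyond the scatter), because a 12-fold lower number from compound 1 to compound 3 (1.08 log units; beyond the scatter) is the only guide available. On that basis compound 4 is expected to give about 1600 nM, with a plausible range from 700 nM to 4000 nM, pending the measurement.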

Compound 4, concentration for 50% growth inhibition: 2510 nM
The estimate for compound 4 lay 1.6-fold (0.20 log units) below the measured number, and the stated range covers the measured number.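

On the core of compound 2, chloro in place of hydrogen on an aromatic carbon, between two ring nitrogen atoms, gave a 7.4-fold lower number from compound 2 to compound 4 (0.87 log units; beyond the scatter) in this assay, so the second chloro group lowered the number on this core as well. Set beside the earlier step, the change carried from one core to the other with no difference in size that can be told apart: the same change on two cores in this assay, a 12-fold lower number (1.08 log units; beyond the scatter) from compound 1 to compound 3 and a 7.4-fold lower number (0.87 log units; beyond the scatter) from compound 2 to compound 4, 1.6-fold (0.21 log units) apart, within the scatter of two such steps. Among these compounds, this rests on only two matched pairs, a single change and a single cell line, so it shows that the step held on these two cores but does not show that it would hold on any other core or in any other cell line, and it gives no reason why the number falls.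

The compounds shown leave open whether an amine or a methoxy group on that same aromatic carbon would lower the number as chloro does. All four compounds also carry the chloromethyl group on the benzyl part, so what a hydroxymethyl or a plain methyl group in its place would give remains an open question.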